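A few compounds are considered here, and "the series" means these few. Any claim that something is new, unique, unknown or untested is made for them only; others in the source may bear on it.

Measured in a functional assay on FaDu cells (Homo sapiens) for cytotoxicity, read by MTT assay, with a stated time of 72 h; a higher number here means that more compound is tolerated, a lower number that less compound is tolerated:
- Compound 1 `COc1ccc2c(c1)c(C(=O)C(=O)Nc1ccc(OC)nc1)cn2C(C)C`: > 10000 nM, a limit of the assay and not a number
- Compound 2 `COc1ccc(NC(=O)C(=O)c2cn(C(C)C)c3ccccc23)nn1`: 2270 nM
- Compound 3 `COc1ccc(NC(=O)C(=O)c2cn(CC3CCO3)c3ccccc23)cn1`: 686 nM

Compound 3 holds the lower of the two true numbers, and its gap to compound 2 lies beyond the scatter. Compound 4 `COc1ccc(NC(=O)C(=O)c2cn(CCOC(C)C)c3ccccc23)cn1` carries isopropoxymethyl in place of oxetan-2-yl on a saturated chain carbon bound to an aromatic nitrogen. Among the measured compounds shown here, no measured step covers this change, so the expectation rests on the span from compound 3 at 686 nM to compound 2 at 2270 nM. A modest rise in this assay is expected, with the estimated step being a 2.0-fold higher number from compound 3 to compound 4 (0.31 log units; beyond the scatter). For compound 4 the estimated value is 1400 nM, with an expected range from 450 nM to 4500 nM.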

Compound 4, concentration lethal to 50% of the cells: 211 nM
Estimate against measurement, compound 4: 6.6-fold (0.82 log units) above, outside the stated range (below it).
By their numbers in this assay, from the lowest: compound 4; then compound 3; then compound 2. At a limit, above all of these: compound 1.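

With isopropoxymethyl in place of oxetan-2-yl on a saturated chain carbon bound to an aromatic nitrogen, this assay gives a 3.3-fold lower number from compound 3 to compound 4 (0.51 log units; beyond the scatter). Among the compounds shown here, this is the first step at this place, and it shows that the four-membered ring can be replaced by an open chain without the number rising. Nothing measured here accounts for the fall.

From the compounds shown here alone, whether an amine, a carboxylic acid or a longer chain at this place would lower the number further remains open. Going by these compounds, it is also open whether this step would recur on a different core.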